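The source may hold more compounds than are shown below. What is called first, only, known or untested is meant among the compounds shown, and "the series" means these compounds.

Measured so far:
compound 1 `CCOc1ccccc1OC(C)C1=NCCN1` — 0.45
compound 2 `C=C(C)c1ccccc1OC(C)C1=NCCN1` — 0.71

In an assay on CHO cells with Alpha-2C adrenergic receptor (Homo sapiens) as the target (a higher number here means a larger maximal response, a lower number a smaller maximal response), compound 2 stands highest of the two numbers; its nearest neighbour is compound 1, the step being a number 0.26 higher from compound 1 to compound 2 (beyond the scatter). Compound 3 `CC(Oc1ccccc1Br)C1=NCCN1` differs from compound 2 by bromo in place of 1-methylethenyl on an aromatic carbon. Within the data shown here, the one measured step that bears on this position is the exchange from compound 1 to compound 2, which moved this assay by a modest amount beyond the scatter; it shows that the group on this aromatic carbon does change the maximal response, but bromo itself has no measured analogue here. The expectation for compound 3 is therefore a small downward step, a number 0.11 lower from compound 2 to compound 3 (beyond the scatter), kept inside the range spanned by compound 1 and compound 2. The estimate for compound 3 in this assay is 0.6, with a range from 0.4 to 0.8.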

Compound 3, intrinsic activity: the largest response reached, as a fraction of the reference agonist's: 0.87
Compound 3: the middle estimate sits 0.27 below what was measured; measured number outside the range, above it.
By their numbers in this assay, from the lowest: compound 1; then compound 2; then compound 3.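

In this assay, bromo on this aromatic carbon gives the largest maximal response of the three compounds, with a number 0.16 higher from compound 2 to compound 3 (beyond the scatter) and a number 0.42 higher from compound 1 to compound 3 (beyond the scatter) for the exchange from ethoxy. Among these compounds, the first pair showed only that the group here changes the response; this result adds that the 3 carbon atoms of 1-methylethenyl and its double bond are not required for a high response, since bromo, with no carbon and no double bond, exceeds it. Nothing available explains the order of ethoxy, 1-methylethenyl and bromo.

Still open, as far as these compounds go, is whether chloro, iodo, an amine or a carboxylic acid on this aromatic carbon would fall above or below bromo. Also open, from the compounds shown here alone, is whether the order of these three groups holds when another part of the shared core changes.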